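Chloro Added on a Second Core: What to Expect

This account rests on a few compounds, and the source may have more. Where it says the series, first, only, none or still open, it means among the compounds named here.

Measured in a functional assay on MCF7 cells (Homo sapiens) for cytotoxicity, read by sulforhodamine B assay, with a stated time of 48 h; on this read-out lower numbers stand for stronger inhibition of growth and higher numbers for weaker inhibition of growth:
compound 1, `COC(=O)c1[nH]c2ccccc2c1C(=O)c1cc(OC)c(OC)c(OC)c1N`: 193 nM
compound 2, `COC(=O)c1[nH]c2ccc(Cl)cc2c1C(=O)c1cc(OC)c(OC)c(OC)c1N`: 171 nM
compound 3, `COc1cc(Cc2c[nH]c3ccccc23)c(N)c(OC)c1OC`: 45000 nM

Compound 2 differs from compound 1 by chloro in place of hydrogen on an aromatic carbon, and this change gave a 1.1-fold lower number from compound 1 to compound 2 (0.05 log units; within the scatter). Compound 3 carries a different core; how the two cores differ is not broken down here, and its number stands far above those of compound 1 and compound 2. Compound 4, `COc1cc(Cc2c[nH]c3ccc(Cl)cc23)c(N)c(OC)c1OC`, is not yet measured. It differs from compound 3 by chloro in place of hydrogen on an aromatic carbon, the same change as between compound 1 and compound 2, at a place described in the same words. The expected step is a 1.1-fold lower number from compound 3 to compound 4 (0.05 log units; within the scatter), because a 1.1-fold lower number from compound 1 to compound 2 (0.05 log units; within the scatter) shows that this change barely moved the number on the first core. Compound 4 is therefore expected to give about 40000 nM in this assay.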

Compound 4, concentration for 50% growth inhibition: "not active" (no number reported)
For compound 4 the study gives words and no number; no gap can be computed for the estimate.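

For the compounds shown here, compound 4 is reported only in words, as "not active", with no number, so no step from compound 3 to compound 4 can be read. How far chloro shifts the number on this core stays open, and no measurement shown offers an explanation.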